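Amide substituent step from compound 2 to compound 3

The source may hold more compounds than are shown below. What is called first, only, known or untested is meant among the compounds shown, and "the series" means these compounds.

Compound 1 `C=CC1=C(C(=O)Nc2ccccc2OC)C(c2ccc(F)cc2)OC1` and compound 2 `C=CC1=C(C(=O)Nc2ccccc2)C(c2ccc(F)cc2)OC1` share a core and differ only on the anilide ring. In a functional assay on QGY7701 cells (Homo sapiens) for cytotoxicity, read by MTT assay, with a stated time of 24 h (a higher number here means a weaker inhibitor, a lower number a stronger inhibitor), compound 1 gives 52800 nM, and compound 2 gives 46700 nM. Among the measured compounds shown here, the step of a 1.1-fold lower number from compound 1 to compound 2 (0.05 log units; within the scatter) is within the scatter, so compound 2 stands at a number indistinguishable from that of compound 1; it is one of only two numbers so far. Compound 3 `C=CC1=C(C(=O)NCCCCC)C(c2ccc(F)cc2)OC1` carries pentyl in place of phenyl on an amide-type nitrogen, read one bond further out as anilino to pentylamino. For the measured compounds named here, no measured step touches the amide nitrogen itself; the only known step, a 1.1-fold lower number from compound 1 to compound 2 (0.05 log units; within the scatter), concerns a substituent on the aromatic ring that now leaves, and it lay within the scatter. The series thus gives no measured basis for a direction, and the expected step of a 1.1-fold higher number from compound 2 to compound 3 (0.03 log units; within the scatter) is taken as none beyond the scatter. Compound 3 is estimated at 50000 nM in this assay, with a range of 15000 nM to 160000 nM.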

Compound 3, half-maximal inhibitory concentration: > 100000 nM
Compound 3: a limit, no number; the forecaster's own chance of this, stated with the estimate: 15%; middle value at least 2.0-fold (0.30 log units) from the limit.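

In this assay compound 3 gives > 100000 nM, which is a limit and not a number. Pentyl in place of phenyl on an amide-type nitrogen gives an at least 2.1-fold higher number from compound 2 to compound 3 (0.33 log units; beyond the scatter), the first step in the series beyond the scatter, so replacing the whole group at this position registers where removing the methoxy from the ring did not. Against compound 1 the same kind of replacement gives an at least 1.8-fold higher number from compound 1 to compound 3 (0.27 log units; that floor lies within the scatter), a floor that stays within the scatter, so only the comparison with compound 2 is firm.

As far as these compounds go, the true size of the step remains unknown, and so does whether it follows from losing the aromatic ring or from the pentyl chain itself. A benzyl or cyclohexyl group, or a shorter chain such as propyl, on the amide-type nitrogen would separate these two readings.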